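Inverting One Ring Stereocentre in a Protected Peptide Mimic

The source may report more compounds than this note shows. Statements on the series, on what has been measured and on what is new or still open speak of the compounds shown alone.

Compound 2 `CC(C)C[C@@H](NC(=O)OC(C)(C)C)C(=O)N1CCC[C@H]1C(=O)N1[C@H](C(=O)OCc2ccccc2)[C@H]1C(=O)OCc1ccccc1` is a protected peptide-like molecule carrying benzyl esters. In a functional assay on J774 cells (Mus musculus) for cytotoxicity, with a stated time of 48 h (a lower number here means a stronger inhibitor, a higher number a weaker inhibitor), compound 2 reaches only a limit of the assay and gives > 100000 nM. Compound 1 `CC(C)(C)OC(=O)NCC(=O)N1CCC[C@@H](C(=O)N2[C@H](C(=O)OCc3ccccc3)[C@H]2C(=O)OCc2ccccc2)C1`, which shares most of the same framework, likewise stops at a limit in this assay and gives > 100000 nM. Compound 3 `CC(C)C[C@@H](NC(=O)OC(C)(C)C)C(=O)N1CCC[C@H](C(=O)N2[C@H](C(=O)O)[C@H]2C(=O)O)C1`, where the esters are replaced by free acids, has "not determined" (no result reported) in this assay. For the measured compounds named here, no step between measured compounds can be drawn here, so compound 2 cannot be placed relative to anything else; all that can be said is that it sits at the same point as compound 1: the limit of > 100000 nM in this assay, at which 2 of the 3 values shown sit.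

Compound 4 `CC(C)C[C@@H](NC(=O)OC(C)(C)C)C(=O)N1CCC[C@@H]1C(=O)N1[C@H](C(=O)OCc2ccccc2)[C@H]1C(=O)OCc1ccccc1` differs from compound 2 in one respect: the two compounds have the same atoms and bonds and differ only in configuration as drawn: 1 of 4 stereo elements differ; a stereocentre at a saturated ring carbon is drawn S in compound 2 and R in compound 4. Nothing measured here connects such a change of configuration to a change in cytotoxicity. Given that compound 2 gives only > 100000 nM, the step from compound 2 to compound 4 is expected to be essentially none beyond the scatter, a step that the limit leaves unreadable from compound 2 to compound 4. Compound 4 is therefore estimated to give about 150000 nM in this assay, within a range from 60000 nM to 400000 nM, and is expected most likely to be reported again only as a limit.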

Compound 4, half-maximal inhibitory concentration: > 100000 nM
Compound 4 ended at the assay's limit; the forecaster's own chance of this, stated with the estimate: 85%; the middle value is on the limit's open side.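

For the compounds shown here, compound 2 and compound 4 both end at a limit in this assay, so no step between them can be read. Compound 4 joins the shared limit: the limit of > 100000 nM in this assay, at which 3 of the 4 values shown sit.

The compounds shown leave open whether inverting this ring stereocentre changes cytotoxicity at all, and at what concentration, if any, such compounds would give a measurable value in this assay.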